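This account rests on a few compounds, and the source may have more. Where it says the series, first, only, none or still open, it means among the compounds named here.

Of the compounds shown here, two sharing one core have so far been tested in an ADME assay on 184B5 cells (Homo sapiens) for cytotoxicity, read by MTT assay, with a stated time of 72 h; a higher number here means a weaker inhibitor of growth, a lower number a stronger inhibitor of growth. Compound 1, `CSc1ccc(CNc2nc(SC)nc3ncccc23)cc1`, gives a measurable result: in this assay compound 1 gives 1140 nM. Compound 2, `CSc1nc(NCCCCCO)c2cccnc2n1`, is the other measured member of the pair. For compound 2 the assay returned only a limit, > 100000 nM, which places compound 2 at the weak end of what this assay can report (the limit of > 100000 nM in this assay, at which 1 of the 2 values shown sits). Compound 3, `CSc1nc(NCc2ccccc2)c2cccnc2n1`, has not yet been measured. It differs from compound 2 in one place: phenyl in place of 4-hydroxybutyl on a saturated chain carbon bound to a nitrogen on an aromatic ring. Among the measured compounds shown here, no step between two measured compounds is available to calibrate this change, so the expectation leans on what the two measured values show. Compound 1, whose structure is close to that of compound 3, gives a real number in this assay, while compound 2 does not. The expected step is therefore a large gain in growth inhibition, an at least 33-fold lower number from compound 2 to compound 3 (1.52 log units; beyond the scatter), with a wide range, as compound 2 sits at a limit. Compound 3 is estimated at 3000 nM, with a range from 800 nM to 15000 nM.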

Compound 3, concentration for total growth inhibition: > 100000 nM
Compound 3: only a limit was reported; the forecaster's own chance of this, stated with the estimate: 15%; middle value at least 33-fold (1.52 log units) away from the limit.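

In this assay, compound 3 gives > 100000 nM, which is a limit of the assay and not a number, so phenyl in place of 4-hydroxybutyl does not by itself bring a measurable result. The readable change lies elsewhere: hydrogen in place of methylsulfanyl on an aromatic carbon gives an at least 87-fold higher number from compound 1 to compound 3 (1.94 log units; beyond the scatter), which ties the measurable result of compound 1 to that one group within this pair. The step between compound 2 and compound 3 cannot be read, and the 4-hydroxybutyl and phenyl compounds cannot be ranked against each other: the limit of > 100000 nM in this assay, at which 2 of the 3 values shown sit.

The compounds shown leave open whether the gain in growth inhibition belongs to methylsulfanyl itself or would come with other groups on that aromatic carbon, and a methoxy group or a chlorine atom there would separate the two. They also leave open whether a chain ending in an amine, in place of 4-hydroxybutyl, would give a measurable number in this assay.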